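A few compounds are considered here, and "the series" means these few. Any claim that something is new, unique, unknown or untested is made for them only; others in the source may bear on it.

Working notes on the series. Compound 1 `Cc1ccc(S(=O)(=O)N/C(=N\O)Nc2ccc(Cl)cc2)cc1` is the reference sulfonyl hydroxyguanidine; in a functional assay on HepG2 cells (Homo sapiens) for cytotoxicity (a higher number here means a weaker inhibitor, a lower number a stronger inhibitor), compound 1 gives 49 ug/mL. Compound 2 `Cc1ccc(S(=O)(=O)N/C(=N\O)Nc2ccc(Cl)c(Cl)c2)cc1` differs by chloro in place of hydrogen on an aromatic carbon and in this assay compound 2 gives 72 ug/mL; the step is a 1.5-fold higher number from compound 1 to compound 2 (0.17 log units; within the scatter), so within the scatter no direction can be read from this pair.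

Compound 3 `Cc1c(S(=O)(=O)/N=C(\S)Nc2ccc(Cl)cc2)sc2ccc(Cl)cc12` carries a different core; the difference between the cores of compound 1 and compound 3 is not broken down here. In this assay compound 3 gives 57 ug/mL, within the scatter of both compound 1 and compound 2.

Compound 4 `Cc1c(S(=O)(=O)/N=C(\S)Nc2ccc(Cl)c(Cl)c2)sc2ccc(Cl)cc12` has not yet been measured. It differs from compound 3 by chloro in place of hydrogen on an aromatic carbon, the same change as that from compound 1 to compound 2, at a place described in the same words. The step of a 1.4-fold higher number from compound 3 to compound 4 (0.15 log units; within the scatter) is expected because the matched step was a 1.5-fold higher number from compound 1 to compound 2 (0.17 log units; within the scatter), and the only anchor is that single pair on the other core. Compound 4 is therefore estimated at 80 ug/mL, expected between 45 ug/mL and 140 ug/mL, pending measurement.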

Compound 4, half-maximal inhibitory concentration: 62 ug/mL
Estimate against measurement, compound 4: 1.3-fold (0.11 log units) above, within the range that was stated.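

In this assay, the change from 4-chlorophenyl to 3,4-dichlorophenyl on the core of compound 3 gives a 1.1-fold higher number from compound 3 to compound 4 (0.04 log units; within the scatter). Set beside the matched step on the core of compound 1, the two steps do not differ: the same change on two cores in this assay, a 1.5-fold higher number (0.17 log units; within the scatter) from compound 1 to compound 2 and a 1.1-fold higher number (0.04 log units; within the scatter) from compound 3 to compound 4, 1.4-fold (0.13 log units) apart, within the scatter of two such steps. This means nothing in the series separates the two cores for this change, but each step lies within the scatter on its own, so no direction can be assigned to the added chloro on either core, and a single pair per core does not show that a change large enough to read would carry across in the same way.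

The compounds shown leave open whether another group at this place on the aromatic ring, such as a methoxy group, an amine or a carboxylic acid, would shift the number beyond the scatter on either core. Also open, on these data alone, is which part of the difference between the cores of compound 1 and compound 3, if any, matters in this read-out.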